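Fluorinating the alcohol end of compound 3

The source may report more compounds than this note shows. Statements on the series, on what has been measured and on what is new or still open speak of the compounds shown alone.

In an in vitro ADME assay on microsomes from liver (Homo sapiens) for metabolic stability, using NADPH (on this read-out lower numbers stand for slow clearance and higher numbers for fast clearance), compound 3 (`CC(O)CCNC(=O)c1cc2cc(C#N)ccc2n1Cc1cccc(OC(F)(F)F)c1`) gives 113 mL.min-1.g-1 and lies within the usual scatter of both compound 1 (`CC(C)(CO)CNC(=O)c1cc2cc(C#N)ccc2n1Cc1cccc(OC(F)(F)F)c1`) at 62 mL.min-1.g-1 and compound 2 (`COc1ccc(C(F)(F)F)cc1Cn1c(C(=O)NCC2(CO)CC2)cc2cc(C#N)ccc21`) at 155 mL.min-1.g-1 alike. Compound 4 (`N#Cc1ccc2c(c1)cc(C(=O)NCCC(O)(C(F)(F)F)C(F)(F)F)n2Cc1cccc(OC(F)(F)F)c1`) has 2,2,2-trifluoro-1-hydroxy-1-(trifluoromethyl)ethyl in place of 1-hydroxyethyl on a saturated chain carbon, two bonds along the chain from an amide-type nitrogen. Among the compounds with values here, the one measured step on this chain (a 1.8-fold higher number from compound 1 to compound 3 (0.26 log units; within the scatter)) lies within the scatter, and no measured compound has fluorine on this chain. No step beyond the scatter is therefore expected in this assay and the estimated step (a 1.3-fold lower number from compound 3 to compound 4 (0.10 log units; within the scatter)) is uncertain. Compound 4 is expected at 90 mL.min-1.g-1 and is estimated to fall from 35 mL.min-1.g-1 to 220 mL.min-1.g-1 on this scale.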

Compound 4, intrinsic clearance in microsomes: 20 mL.min-1.g-1
Estimate against measurement, compound 4: 4.5-fold (0.65 log units) above, and the stated range ends above it.
By their numbers in this assay, from the lowest: compound 4; then compounds 1, 3 and 2 (each within the scatter of the next, the first and the last beyond it).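

In this assay, within the data shown here, the one earlier step on this chain stayed within the scatter, whereas 2,2,2-trifluoro-1-hydroxy-1-(trifluoromethyl)ethyl in place of 1-hydroxyethyl gives a step beyond it (a 5.7-fold lower number from compound 3 to compound 4 (0.75 log units; beyond the scatter)). Read against the branched chain, 3,3,3-trifluoro-2-hydroxy-2-(trifluoromethyl)propyl also gives a step beyond the scatter (a 3.1-fold lower number from compound 1 to compound 4 (0.49 log units; beyond the scatter)), so changing this end of the chain can lower the clearance number. No measurement shown explains this result. On these data alone, it remains open whether one trifluoromethyl would give a similar step, since both arrive together here. An amine in place of the hydroxyl also remains untested among these compounds.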